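Swapping Pyrrole for Thiophene: Expected Cytotoxicity of Compound 4

The compounds below may be only part of what the source reports. "The series", "measured", "known", "first", "only" and "open" are said of these compounds alone.

Measured compounds:
Compound 1 `COC1=CC(c2cccs2)=N/C1=C\c1ccc[nH]1`: in a functional assay on PLC5 cells (Homo sapiens) for cytotoxicity, read by MTT assay (a lower number here means a stronger inhibitor, a higher number a weaker inhibitor), compound 1 gives > 40000 nM, which is a limit of the assay and not a number.
Compound 2 `COC1=CC(c2cc3ccccc3[nH]2)=N/C1=C\c1ccc[nH]1`: in this assay compound 2 gives 13200 nM.
Compound 3 `COC1=CC(c2cccs2)=N/C1=C\c1cccs1`: in this assay compound 3 gives 25900 nM.

Compound 2 holds the lowest of the two numbers, but compound 3 stands within the scatter of it, so the two cannot be ordered. Compound 1 sits at the limit of > 40000 nM in this assay, at which 1 of the 3 values shown sits. The change from compound 1 to compound 3 is thiophen-2-yl in place of 1H-pyrrol-2-yl on a double-bonded chain carbon bound to a double-bonded ring carbon, and it made an at least 1.5-fold lower number from compound 1 to compound 3 (0.18 log units; that floor lies within the scatter).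

Compound 4 `COC1=CC(c2cc3ccccc3[nH]2)=N/C1=C\c1cccs1` carries the same change on the core of compound 2: thiophen-2-yl in place of 1H-pyrrol-2-yl on a double-bonded chain carbon bound to a double-bonded ring carbon. The difference between the two cores is not broken down here.

In this assay the step from compound 2 to compound 4 is expected to be a 1.7-fold lower number from compound 2 to compound 4 (0.22 log units; within the scatter), beside the earlier step of an at least 1.5-fold lower number from compound 1 to compound 3 (0.18 log units; that floor lies within the scatter), because that step rests on compound 1 standing at the limit of > 40000 nM in this assay, at which 1 of the 3 values shown sits, and its floor lies within the scatter. Compound 4 is therefore estimated at 8000 nM, with a likely range from 3000 nM to 25000 nM.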

Compound 4, half-maximal inhibitory concentration: > 40000 nM
Compound 4: only a limit was reported; the forecaster's own chance of this, stated with the estimate: 8%; middle value at least 5.0-fold (0.69 log units) away from the limit.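

On the core of compound 2, thiophen-2-yl in place of 1H-pyrrol-2-yl gave an at least 3.0-fold higher number from compound 2 to compound 4 (0.48 log units; beyond the scatter) in this assay, so this change did not carry over from the core of compound 1 as a constant step, and the two steps differ: the same change on two cores in this assay, an at least 1.5-fold lower number (0.18 log units; that floor lies within the scatter) from compound 1 to compound 3 and an at least 3.0-fold higher number (0.48 log units; beyond the scatter) from compound 2 to compound 4, at least 4.6-fold (0.67 log units) apart, beyond the scatter of two such steps

Compound 4 gives > 40000 nM, which is a limit of the assay and not a number. Compound 1 stands at that same limit, so the true size of neither step is known, and nothing here shows why the two cores answer differently: the limit of > 40000 nM in this assay, at which 2 of the 4 values shown sit.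

The compounds shown leave open what an amine or a carboxylic acid would do on the double-bonded chain carbon bound to a double-bonded ring carbon, on either core. They also leave open whether, on a further core, the same change would follow the step seen on the core of compound 1 or the one seen on the core of compound 2.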